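The source may report more compounds than this note shows. Statements on the series, on what has been measured and on what is new or still open speak of the compounds shown alone.

Of the compounds shown here, three sharing the same sugar-bearing core have been tested in a functional assay on HepG2 cells (Homo sapiens) for antiproliferative activity, read by XTT assay, with a stated time of 72 h; a higher number here means a weaker inhibitor, a lower number a stronger inhibitor. Compound 1, `Nc1nc2c(c(-c3ccccc3)cn2[C@@H]2O[C@H](CO)[C@@H](O)[C@H]2O)c(=O)[nH]1`, gives only a limit in this assay, > 20000 nM. Compound 2, `Cc1ncnc2c1c(-c1cccs1)cn2[C@@H]1O[C@H](CO)[C@@H](O)[C@H]1O`, likewise reaches only a limit in this assay, > 15000 nM. Compound 3, `Cc1nc(N)c2c(-c3ccsc3)cn([C@@H]3O[C@H](CO)[C@@H](O)[C@H]3O)c2n1`, also stops at a limit in this assay, > 20000 nM. Compound 1 therefore stands together with compound 3 at the limit of > 20000 nM in this assay, at which 2 of the 3 values shown sit, while compound 2 sits at the limit of > 15000 nM in this assay, at which 1 of the 3 values shown sits. For the measured compounds named here, since none of the three yields a number, no step between measured compounds can be read, and the set gives no ground to rank one compound against another.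

Compound 4, `Nc1nc2c(c(-c3ccsc3)cn2[C@@H]2O[C@H](CO)[C@@H](O)[C@H]2O)c(=O)[nH]1`, is the untested member. It differs from compound 1 in a single place: thiophen-3-yl in place of phenyl on an aromatic carbon. The same thiophen-3-yl group already appears in compound 3, which in this assay gave only a limit, > 20000 nM. With every neighbour in the set at a limit, the step from compound 1 to compound 4 is expected to be none beyond the scatter, a step that the limit leaves unreadable from compound 1 to compound 4. Compound 4 is accordingly estimated to sit at 30000 nM, within a range of 10000 nM to 100000 nM, most likely reported again only as a limit in this assay.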

Compound 4, half-maximal inhibitory concentration: > 20000 nM
Compound 4: no number, only a limit; the forecaster's own chance of this, stated with the estimate: 85%; the middle value does not contradict the limit.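

In this assay compound 4 gives only a limit, > 20000 nM. For the compounds shown here, compound 1 also stands at a limit, so no step from compound 1 to compound 4 can be read. The compounds shown leave open how thiophen-3-yl and phenyl on this aromatic carbon compare, and what potency any of these compounds has in this assay.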